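The source may report more compounds than this note shows. Statements on the series, on what has been measured and on what is new or still open speak of the compounds shown alone.

Measured so far, in a functional assay on Ehrlich cells (Mus musculus) for cytotoxicity, read by trypan blue exclusion, with a stated time of 2 h, tested at 100 ug/mL; a lower number here means a weaker effect, a higher number a stronger effect of the compound at the concentration tested:

- compound 1, `N#CC1=C(N)N(c2ccc(S(N)(=O)=O)cc2)C2=C(C(=O)CCC2)C1c1ccc(Cl)cc1Cl`: 95%
- compound 2, `CCCCNC(=S)NC1=C(C#N)C(c2ccc(Cl)cc2Cl)C2=C(CCCC2=O)N1c1ccc(S(N)(=O)=O)cc1`: 40%
- compound 3, `N#CC1=C(NC(=S)Nc2ccccc2)N(c2ccc(S(N)(=O)=O)cc2)C2=C(C(=O)CCC2)C1c1ccc(Cl)cc1Cl`: 95%

Compound 3 stands level with compound 1 at the digits shown, the two together giving the highest numbers of the three; its distance from compound 2 is a number 55 percentage points higher from compound 2 to compound 3 (beyond the scatter), a large step that follows from phenyl in place of butyl on the thiourea nitrogen. The step of no change at the digits printed from compound 1 to compound 3 (within the scatter) shows that attaching the phenylthiourea to the amine of compound 1 leaves this assay unchanged, whereas a number 55 percentage points lower from compound 1 to compound 2 (beyond the scatter) shows the butyl analogue falling far.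

Compound 4, `N#CC1=C(NC(=S)Nc2ccc(Br)cc2)N(c2ccc(S(N)(=O)=O)cc2)C2=C(C(=O)CCC2)C1c1ccc(Cl)cc1Cl`, differs from compound 3 in one place: bromo in place of hydrogen on an aromatic carbon. Within the data shown here, none of the measured steps changes this ring itself; all of them concern what sits on the thiourea nitrogen. The bromo enters at a position that is already occupied by the phenyl ring in compound 3, the compound at the top of the range, so the step is expected to stay within the scatter, a number 5 percentage points lower from compound 3 to compound 4 (within the scatter). Compound 4 is therefore estimated at 90%, with a range from 65% to 100%.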

Compound 4, a percentage reported as activity, at one concentration (the size of the read-out at that concentration, not a potency): 90%
Compound 4: the middle estimate sits on the measured number at the digits printed; the measured number falls inside the stated range.
By their numbers in this assay, from the lowest: compound 2; then compounds 4, 1 and 3 (each within the scatter of the next).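

The earlier compounds shown here changed only what sits on the thiourea nitrogen, whereas here the phenyl ring itself is altered. In this assay, bromo in place of hydrogen on this ring, para to a large group, gives a number 5 percentage points lower from compound 3 to compound 4 (within the scatter). The separation from the butyl analogue also survives the change, with 4-bromophenyl in place of butyl giving a number 50 percentage points higher from compound 2 to compound 4 (beyond the scatter), while the full group added to the amine nitrogen of compound 1 gives a number 5 percentage points lower from compound 1 to compound 4 (within the scatter); no available data offer an explanation for these numbers.

The compounds shown leave open whether this ring position would accept other groups, such as methoxy, nitro or a carboxylic acid. A read-out at one concentration also does not tell whether compound 1, compound 3 and compound 4 would differ in effect at other concentrations.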